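The source may hold more compounds than are shown below. What is called first, only, known or untested is meant among the compounds shown, and "the series" means these compounds.

Working notes on the acylhydrazone series. Compound 1 `CN(C)CCn1cnnc1-c1cc(Oc2ccc(NC(=O)N/N=C/c3c[nH]c4ccccc34)cc2F)ccn1` gives 690 nM in a functional assay on U-87MG ATCC cells (Homo sapiens) for cytotoxicity, read by MTT assay, with a stated time of 72 h; on this read-out higher numbers stand for weaker inhibition and lower numbers for stronger inhibition. Compound 2 `CN(C)CCn1cnnc1-c1cc(Oc2ccc(NC(=O)N/N=C/c3ccc(F)cc3)cc2F)ccn1` gives 2310 nM in this assay, and compound 3 `CN(C)CCn1cnnc1-c1cc(Oc2ccc(NC(=O)N/N=C/c3ccc(F)cc3F)cc2F)ccn1` gives 1900 nM in this assay. Compound 3 thus holds the second-highest of the three numbers, close to compound 2 and well separated from compound 1; the step of a 2.8-fold higher number from compound 1 to compound 3 (0.44 log units; beyond the scatter) and the step of a 3.3-fold higher number from compound 1 to compound 2 (0.52 log units; beyond the scatter) both show that the indolyl compound sits apart, while the step of a 1.2-fold lower number from compound 2 to compound 3 (0.08 log units; within the scatter) shows the two fluorophenyl compounds are indistinguishable.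

Compound 4 `CN(C)CCn1cnnc1-c1cc(Oc2ccc(NC(=O)N/N=C/c3cc(Br)c(O)c(Br)c3)cc2F)ccn1` carries the change (3,5-dibromo-4-hydroxyphenyl in place of 2,4-difluorophenyl on a carbon with a double bond to nitrogen). Within the data shown here, no measured step swaps one substituted phenyl for another substituted phenyl bearing a hydroxyl and halogens; the only aryl-for-aryl step that stays within phenyl is a 1.2-fold lower number from compound 2 to compound 3 (0.08 log units; within the scatter), which did not move beyond the scatter. Compound 4 is therefore expected to stay near compound 3, with the estimated step of a 1.2-fold lower number from compound 3 to compound 4 (0.07 log units; within the scatter) in this assay. Compound 4 is estimated at 1600 nM in this assay, with a range of 500 nM to 5000 nM.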

Compound 4, half-maximal inhibitory concentration: > 100000 nM
Compound 4: a limit, no number (the forecaster's own chance of this, stated with the estimate: 5%); middle value at least 62-fold (1.79 log units) from the limit.
By their numbers in this assay, from the lowest: compound 1; then compounds 3 and 2 (each within the scatter of the next). At a limit, above all of these: compound 4.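

This position tolerates less than the two fluorophenyl compounds suggested: with 3,5-dibromo-4-hydroxyphenyl in place, the steps of an at least 52-fold higher number from compound 3 to compound 4 (1.72 log units; beyond the scatter) and an at least 43-fold higher number from compound 2 to compound 4 (1.63 log units; beyond the scatter) are both large in this assay, so a change that stays within substituted phenyl can matter greatly here. The step of an at least 140-fold higher number from compound 1 to compound 4 (2.16 log units; beyond the scatter) is also large, so this change reaches well beyond the gap that separated the 1H-indol-3-yl compound from the fluorophenyl compounds. The reading for compound 4 is a limit and not a number: the limit of > 100000 nM in this assay, at which 1 of the 4 values shown sits.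

This change replaces the fluoro groups with bromo groups and adds a hydroxyl in one step, so the compounds shown do not separate the contribution of the hydroxyl from that of the bromines. On these data alone, whether 4-hydroxyphenyl, 3,5-dibromophenyl or a phenyl carrying an amine or a carboxylic acid would stay near compound 3 remains open.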